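The source may hold more compounds than are shown below. What is called first, only, known or untested is meant among the compounds shown, and "the series" means these compounds.

Three compounds share one core and differ only in the aryl group carried on the carbonyl carbon. Compound 1 `O=C(/C=C/c1cn(-c2ccccc2)nc1-c1ccsc1)c1ccccc1` gives 1900 nM in a functional assay on MCF7 cells (Homo sapiens) for inhibition, read by sulforhodamine B assay, with a stated time of 72 h; on this read-out lower numbers stand for stronger inhibition and higher numbers for weaker inhibition. Compound 2 `O=C(/C=C/c1cn(-c2ccccc2)nc1-c1cccnc1)c1ccsc1` gives 500 nM in this assay, and compound 3 `O=C(/C=C/c1cn(-c2ccccc2)nc1-c1cccnc1)c1ccccn1` gives 4200 nM in this assay, the highest number of the three. Among the compounds with values here, the single measured step that bears on the next change is an 8.4-fold higher number from compound 2 to compound 3 (0.92 log units; beyond the scatter). Compound 4 `O=C(/C=C/c1cn(-c2ccccc2)nc1-c1cccnc1)c1cc[nH]c1` differs from compound 3 by 1H-pyrrol-3-yl in place of pyridin-2-yl on a carbonyl carbon. The entering 1H-pyrrol-3-yl, a five-membered aromatic ring with one hetero atom, is closer in kind to the thiophen-3-yl of compound 2 than to the leaving six-membered pyridin-2-yl, so part of the ground lost from compound 2 to compound 3 might be regained, although the entering hydrogen-bond donor has no measured counterpart among these compounds and the estimate is accordingly wide. Compound 4 is therefore expected to show a 2.8-fold lower number from compound 3 to compound 4 (0.45 log units; beyond the scatter). The estimate for compound 4 in this assay is 1500 nM, between 500 nM and 4500 nM.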

Compound 4, half-maximal inhibitory concentration: 6900 nM
The estimate for compound 4 lay 4.6-fold (0.66 log units) below the measured number; the measured number lies above the stated range.
By their numbers in this assay, from the lowest: compound 2; then compound 1; then compounds 3 and 4 (each within the scatter of the next).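

In this assay the change from pyridin-2-yl to 1H-pyrrol-3-yl gives a 1.6-fold higher number from compound 3 to compound 4 (0.22 log units; within the scatter) and thus leaves the two groups indistinguishable on the carbonyl carbon, whereas the change from thiophen-3-yl gives a 14-fold higher number from compound 2 to compound 4 (1.14 log units; beyond the scatter) and sets them clearly apart. At this position, then, a five-membered aromatic ring with one hetero atom does not by itself keep the low number of compound 2, since 1H-pyrrol-3-yl shares that description with thiophen-3-yl yet stays level with the six-membered pyridin-2-yl. Nothing available explains why the two five-membered rings differ so widely.

Still open, on these data alone, is where a furan-3-yl or a 1-methyl-1H-pyrrol-3-yl would fall on the carbonyl carbon, nearer compound 2 or nearer compound 4. Also open, as far as these compounds go, is whether thiophen-3-yl keeps its lead over 1H-pyrrol-3-yl when the pyridin-3-yl-bearing core carries a different group, such as a methoxy or a chlorine, on its phenyl ring.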